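The source may report more compounds than this note shows. Statements on the series, on what has been measured and on what is new or still open speak of the compounds shown alone.

Measured compounds:
Compound 1, `CCCC(=O)NCCC(=O)c1cc(OC)ccc1N`, in an assay for inhibition of Nitric oxide synthase, inducible (Homo sapiens), read by scintillation counting, with a stated time of 30 min, tested at 1 mM (a higher number here means more inhibition at the concentration tested (going by the name of the read-out), a lower number less inhibition), gives 7.35%.
Compound 2, `CCCCC(=O)NCCC(=O)c1cc(OC)ccc1N`, in this assay gives 14.1%.

Of the two numbers, compound 2 shows the higher one, but the step of a number 6.8 percentage points higher from compound 1 to compound 2 (within the scatter) lies within the scatter, so the two compounds cannot be placed in order. Compound 3, `COc1ccc(N)c(C(=O)CCNC(=O)C2CCCC2)c1`, is not yet measured. It differs from compound 2 in one place: cyclopentyl in place of butyl on a carbonyl carbon. Going by the values given here, the only measured step, a number 6.8 percentage points higher from compound 1 to compound 2 (within the scatter), changed the same saturated chain and produced nothing beyond the scatter. Among the compounds with values here, no measured step replaces a chain by a ring, so the change from butyl to cyclopentyl has no direct precedent here. On that basis compound 3 is expected to give a number in this assay close to that of compound 2, with the step of a number 0.9 percentage points higher from compound 2 to compound 3 (within the scatter) expected to remain within the scatter. The estimate for compound 3 is 15%, with a range from 3% to 30%.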

Compound 3, a percentage reported as inhibition, at one concentration (the size of the read-out at that concentration, not a potency): 0.61%
Estimate against measurement, compound 3: 14.4 percentage points above, outside the stated range (below it).
By their numbers in this assay, from the lowest: compounds 3, 1 and 2 (each within the scatter of the next, the first and the last beyond it).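

In this assay, going by these compounds alone, the change on this carbonyl carbon now gives a step beyond the scatter for the first time: cyclopentyl in place of butyl gives a number 13.5 percentage points lower from compound 2 to compound 3 (beyond the scatter) and so separates a ring from a chain of similar size. Cyclopentyl in place of propyl gives a number 6.7 percentage points lower from compound 1 to compound 3 (within the scatter) and leaves those two compounds without an order, so the ring stands apart from butyl only and the three compounds form no clear ranking. No evidence is available that accounts for this difference between the ring and the chain.

The compounds shown leave open whether a longer chain such as hexyl would continue the numbers seen with propyl and butyl, and whether cyclohexyl would match cyclopentyl. They also leave open how a chain ending in an amine or a carboxylic acid would read at this same carbonyl carbon.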